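Removing one methyl from compound 1

A few compounds are considered here, and "the series" means these few. Any claim that something is new, unique, unknown or untested is made for them only; others in the source may bear on it.

Measured in a functional assay on cells (Renal cancer cell line, Homo sapiens) for cytotoxicity, read by sulforhodamine B assay, with a stated time of 48 h; on this read-out lower numbers stand for stronger inhibition of growth and higher numbers for weaker inhibition of growth:
- compound 1 `COc1cc2c(cc1C)NC(=O)/C2=C/c1c(OC)nc2sc(C)cn12`: 5810 nM
- compound 2 `COc1nc2sc(C)cn2c1C=C1C(=O)N(C)c2ccccc21`: 13100 nM
- compound 3 `O=C1Nc2ccccc2C1=Cc1c(-c2ccncc2)nc2sccn12`: 14900 nM

Compound 1 gives the lowest number of the three, at 5810 nM. Its gaps to compound 2 and to compound 3 both lie beyond the scatter, whereas those two values lie within the scatter of each other. Going by the values given here, no two measured compounds differ in only one place, so the series gives no direct measure of what a single change does.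

The next compound is compound 4 `COc1ccc2c(c1)/C(=C\c1c(OC)nc3sc(C)cn13)C(=O)N2`, not yet measured in this assay. It keeps the core of compound 1 and has hydrogen in place of methyl on an aromatic carbon. The methoxy group stays in place.

Neither compound 2 nor compound 3 carries a methyl or a methoxy group on that aromatic ring, but both differ from compound 1 elsewhere as well, so their values offer only weak guidance. A change of a single methyl is expected to do little, with a slight drift towards a higher number, possibly none beyond the scatter. The expected step is a 1.4-fold higher number from compound 1 to compound 4 (0.14 log units; within the scatter).

For compound 4 the estimated value is 8000 nM, with an expected range of 3500 nM to 18000 nM.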

Compound 4, concentration for 50% growth inhibition: 650 nM
Beside the measured number, compound 4's estimate is 12-fold (1.09 log units) above it, outside the stated range (below it).
By their numbers in this assay, from the lowest: compound 4; then compound 1; then compounds 2 and 3 (each within the scatter of the next).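

In this assay, going by these compounds alone, replacing methyl by hydrogen gives an 8.9-fold lower number from compound 1 to compound 4 (0.95 log units; beyond the scatter) and provides the first direct reading of a single change. It shows that this aromatic carbon, ortho to a methoxy group, is sensitive: with the methoxy group and the rest of the core of compound 1 unchanged, the loss of one methyl moves the read-out well beyond the scatter. The data at hand offer no measurement that explains this step.

From the compounds shown here alone, whether hydrogen itself is the preferred group here remains open, since a fluorine, a chlorine, an ethyl or a hydroxyl on this carbon would show whether the read-out follows the size of the group or simply the absence of methyl. Also open, going by these compounds, is whether the methoxy group is needed for this step, which a compound with hydroxyl or ethoxy in its place would test, and whether the same replacement holds when the other parts of the core of compound 1 are changed.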